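The compounds below may be only part of what the source reports. "The series", "measured", "known", "first", "only" and "open" are said of these compounds alone.

Working notes on the series. All three measured compounds share the same core as compound 1 `COc1ccc(N(CC(=O)NCCC[Te]c2ccccc2)C(=O)CNC(=O)OC(C)(C)C)cc1`, and all were tested in a functional assay on SN12C cells (Homo sapiens) for inhibition, with a stated time of 48 h; a lower number here means that less compound is tolerated, a higher number that more compound is tolerated. Compound 1 gives only a limit of < 100000 nM there, which is the assay's limit rather than a number; this is the case noted in the limit of < 100000 nM in this assay, at which 1 of the 3 values shown sits. Compound 2 `COc1ccc(N(CC(=O)NCCC[Te]c2ccccc2)C(=O)CCSC2=C(C)C(=O)c3ccccc3C2=O)cc1` gives 23400 nM in this assay. Compound 3 `CC1=C(SCCC(=O)OCC(=O)NCCC[Te]c2ccccc2)C(=O)c2ccccc2C1=O` gives 31600 nM in this assay. Compound 2 and compound 3 sit within the usual scatter of each other, so no order between them is read. For the measured compounds named here, no pair among the measured compounds differs in a single place, so no measured step is available.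

Compound 4 `COc1ccc(N(CC(=O)NCCC[Te]c2ccccc2)C(=O)c2ccccc2)cc1` has not yet been measured. It differs from compound 1 by phenyl in place of ((tert-butoxycarbonyl)amino)methyl on a carbonyl carbon. Going by the values given here, with no measured step to lean on and only a limit for compound 1, the direction of the step is open; the expectation is that the step from compound 1 to compound 4 in this assay, a step that the limit leaves unreadable from compound 1 to compound 4, stays within the range spanned by compound 2 and compound 3 and the limit of compound 1. Compound 4 is therefore estimated at 40000 nM in this assay, with a range from 10000 nM to 100000 nM, the uncertainty being wide.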

Compound 4, concentration lethal to 50% of the cells: < 100000 nM
Compound 4: no number, only a limit (the forecaster's own chance of this, stated with the estimate: 30%); the middle value lies beyond the limit too.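

Compound 1 and compound 4 each give only a limit in this assay, so no step between them can be read: the limit of < 100000 nM in this assay, at which 2 of the 4 values shown sit.

The compounds shown leave open whether phenyl in place of ((tert-butoxycarbonyl)amino)methyl on this carbonyl carbon changes the value in this assay at all.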